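Acetyl and methoxy aryl change from compound 2 to compound 3

The source may report more compounds than this note shows. Statements on the series, on what has been measured and on what is new or still open speak of the compounds shown alone.

In a functional assay (aorta) with Oryctolagus cuniculus as the target (on this read-out higher numbers stand for weaker binding and lower numbers for tighter binding), compound 1 (`COc1cc(C(C)=O)ccc1OCCCN1CCC(C(c2cccc(F)c2)c2cccc(F)c2)CC1`) gives 3.16 nM and compound 2 (`CCc1ccc(OCCCN2CCC(C(c3ccc(F)cc3)c3ccc(F)cc3)CC2)c(OC)c1`) gives 2.51 nM within the scatter of each other, so compound 2 stands level with compound 1. Compound 3 (`COc1cc(OCCCN2CCC(C(c3ccc(F)cc3)c3ccc(F)cc3)CC2)ccc1C(C)=O`) carries 4-acetyl-3-methoxyphenyl in place of 4-ethyl-2-methoxyphenyl on an oxygen on a saturated carbon. Among the compounds with values here, no measured pair of compounds isolates this change, so the expectation rests on little. Within the data shown here, compound 1, which also carries an acetyl group, gives 3.16 nM and so offers no ground for expecting a large step, though no measured compound carries the 4-acetyl-3-methoxyphenyl group. A modest move towards a higher number is expected, with a 2.4-fold higher number from compound 2 to compound 3 (0.38 log units; beyond the scatter) as the estimated step in this assay for now. For compound 3 the estimated value is 6 nM with 1.5 nM to 25 nM as the expected range.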

Compound 3, dissociation constant: 3.16 nM
Estimate against measurement, compound 3: 1.9-fold (0.28 log units) above; low and high end bracket the measured number.
By their numbers in this assay, from the lowest: compounds 2, 1 and 3 (each within the scatter of the next).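

In this assay, placing 4-acetyl-3-methoxyphenyl in place of 4-ethyl-2-methoxyphenyl on an oxygen on a saturated carbon gives a 1.3-fold higher number from compound 2 to compound 3 (0.10 log units; within the scatter) as the first step read in the series, so this position accepts this exchange without a readable difference. The entering group has more heavy atoms and more hydrogen-bond acceptors than the leaving group, and neither difference comes with a shift beyond the scatter in this pair. No supporting measurement accompanies this result.

The pair changes the acetyl and ethyl groups and the methoxy placement together, so the contribution of each remains unresolved. Also open, going by these compounds, is whether the same position would accept a carboxylic acid or an amine in place of the acetyl group.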